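From Phenoxy to Methoxy, Without a Measured Baseline

A few compounds are considered here, and "the series" means these few. Any claim that something is new, unique, unknown or untested is made for them only; others in the source may bear on it.

Compound 1 `COc1ccc(-c2cn(-c3ccc(Oc4ccccc4)cc3)nn2)cc1` and compound 2 `COc1cc(-c2cn(-c3ccc(Oc4ccccc4)cc3)nn2)ccc1O` share a core and differ in the groups around it. In a functional assay on MDA-MB-231 cells (Homo sapiens) for cytotoxicity, read by MTT assay (a higher number here means a weaker inhibitor, a lower number a stronger inhibitor), compound 1 gives > 100 nM, which is a limit of the assay and not a number. Among the compounds with values here, for compound 2 the entry reads "not determined" (no result reported), so compound 2 has no standing of its own on the numbers, and no measured step starts from it.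

Compound 3 `COc1ccc(-n2cc(-c3ccc(O)c(OC)c3)nn2)cc1` is the next structure. The change is methyl in place of phenyl on an oxygen on an aromatic ring, which puts methyl in place of phenyl on an oxygen on an aromatic ring, phenoxy to methoxy.

Within the data shown here, with no measured step to scale from, the only guide is the limit of > 100 nM in this assay, at which 1 of the 2 values shown sits. A shift in this assay of no firm direction, and none beyond the scatter of that region, is expected. Compound 3 is estimated at 150 nM, with an expected range from 40 nM to 600 nM.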

Compound 3, half-maximal inhibitory concentration: > 10000 nM
Compound 3: no number, only a limit (the forecaster's own chance of this, stated with the estimate: 50%); at least 66-fold (1.82 log units) between middle value and limit.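

In this assay compound 3 gives > 10000 nM, which is a limit of the assay and not a number. Within the data shown here, compound 2 carries no value, so no step from it to compound 3 can be read. The compounds shown leave open what phenoxy to methoxy does in this assay.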